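From compound 2 to compound 3: an aryl exchange

The source may report more compounds than this note shows. Statements on the series, on what has been measured and on what is new or still open speak of the compounds shown alone.

In a functional assay on MIA PaCa-2 cells (Homo sapiens) for inhibition, read by MTT assay, with a stated time of 48 h, tested at 10 uM (on this read-out lower numbers stand for less inhibition of growth and higher numbers for more inhibition of growth at the one concentration tested), compound 1 (`CCN(CC)Cc1c(O)c([C@H]2CCN(C)C[C@H]2O)c2oc(C)cc(=O)c2c1O`) gives 27% while compound 2 (`Cc1oc2c([C@H]3CCN(C)C[C@H]3O)c(O)cc(O)c2c(=O)c1C(O)c1ccc(Cl)cc1`) gives 15% at the one concentration tested. Compound 2 therefore holds the lower of the two numbers, and the gap to compound 1 lies beyond the usual scatter. These two compounds differ in more than one place, so the pair does not isolate any single structural change.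

Compound 3 (`COc1ccc(C(O)c2c(C)oc3c([C@H]4CCN(C)C[C@H]4O)c(O)cc(O)c3c2=O)cc1Br`) has not yet been measured. Its difference from compound 2 is 3-bromo-4-methoxyphenyl in place of 4-chlorophenyl on a saturated chain carbon bound to an aromatic carbon and an oxygen on a saturated carbon and reads 3-bromo-4-methoxyphenyl in place of 4-chlorophenyl on a saturated chain carbon bound to an aromatic carbon and an oxygen on a saturated carbon. For the measured compounds named here, no measured pair shows what such an exchange does in this assay and the expectation therefore rests on compound 2 at 15% alone. No shift beyond the scatter is expected in either direction. The expected change is a number 3 percentage points higher from compound 2 to compound 3 (within the scatter) and it would stay within the scatter. For compound 3 the estimate is 18% with 5% to 35% as the expected range.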

Compound 3, percent growth inhibition at one concentration: 3%
Compound 3: the middle estimate sits 15 percentage points above what was measured, and the stated range ends above it.
By their numbers in this assay, from the lowest: compound 3; then compound 2; then compound 1.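

For the compounds shown here, the exchange of 4-chlorophenyl for 3-bromo-4-methoxyphenyl on a saturated chain carbon bound to an aromatic carbon and an oxygen on a saturated carbon gives the first single-place step: in this assay it reads a number 12 percentage points lower from compound 2 to compound 3 (beyond the scatter) and so goes toward less inhibition of growth. This position is therefore not indifferent to the aryl group it carries, which the earlier pair, differing in more than one place, could not show. No supporting data bear on why this exchange lowers the number.

Because one step changes the aryl group in more than one way, the bromine and the methoxy group cannot be separated, and the series shown holds neither a 3-bromophenyl nor a 4-methoxyphenyl compound to divide the step between them. Also open, from the compounds shown here alone, is how this position responds to an aryl group carrying an amine or a carboxylic acid, or to a longer chain in place of the aryl group, as well as whether the step holds at concentrations other than the one tested.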